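A few compounds are considered here, and "the series" means these few. Any claim that something is new, unique, unknown or untested is made for them only; others in the source may bear on it.

Measured compounds:
- compound 1, `O=C(Nc1ccccc1)OC1CCN(Cc2ccccc2)CC1`, gives > 100000 nM in an assay on BTI-TN-5B1-4 cells for inhibition of Amine oxidase [flavin-containing] B (Homo sapiens), read by fluorescence and Amplex Red, using microsomes, with a stated time of 15 min (a lower number here means a stronger inhibitor, a higher number a weaker inhibitor), which is a limit of the assay and not a number.
- compound 2, `C#CCN1CCC(OC(=O)Nc2ccc(C(C)C)cc2)CC1`, gives 178 nM in this assay.

Going by the values given here, compound 2 stands alone as the only number in this assay; the one other value shown, that of compound 1, sits at the limit of > 100000 nM in this assay, at which 1 of the 2 values shown sits. The step to compound 3, `CC(C)c1ccc(NC(=O)OC2CCN(Cc3ccccc3)CC2)cc1`, leaves the carbamate and the ring untouched and changes only the group on the ring nitrogen: phenyl in place of ethynyl on a saturated chain carbon bound to an amine nitrogen in a ring. Among the compounds with values here, compound 1 also carries a benzyl group on that nitrogen, and in this assay compound 1 gives only the limit noted above, so no measured step tells how the swap from propargyl to benzyl plays out on its own. On the evidence shown, a loss of potency well beyond the scatter is expected from compound 2 to compound 3, as a 110-fold higher number from compound 2 to compound 3 (2.05 log units; beyond the scatter). Compound 3 is therefore estimated at 20000 nM in this assay, within a range of 3000 nM to 100000 nM, with a real chance that the assay reports only a limit.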

Compound 3, half-maximal inhibitory concentration: > 100000 nM
Compound 3: a limit, no number; the forecaster's own chance of this, stated with the estimate: 40%; at least 5.0-fold (0.69 log units) between middle value and limit.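

With the isopropyl group and the carbamate held fixed, the change from propargyl to benzyl on the amine nitrogen in a ring now has a measured size in this assay, where the step reads as an at least 560-fold higher number from compound 2 to compound 3 (2.74 log units; beyond the scatter). Compound 3 gives > 100000 nM, which is a limit of the assay and not a number, so adding the isopropyl group to the benzyl compound does not bring it to a readable value in this assay. The step between the two benzyl compounds cannot be read, as both rest on the same limit: the limit of > 100000 nM in this assay, at which 2 of the 3 values shown sit.

The compounds shown leave open whether the ethynyl group itself is needed for a readable value, or whether a simple propyl or methyl group on the same nitrogen, or a chain ending in a nitrile, would serve as well. Also open, on these data alone, is what a propargyl compound would give with hydrogen in place of isopropyl on the aromatic carbon, and so how much of the value of compound 2 rests on that isopropyl group.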